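The source may report more compounds than this note shows. Statements on the series, on what has been measured and on what is new or still open speak of the compounds shown alone.

Compound 1 `CC(C)(C)N(NC(=O)c1ccccc1)C(=O)c1ccccc1I` — 105 nM
Compound 2 `COc1ccccc1C(=O)N(NC(=O)c1ccccc1)C(C)(C)C` — 525 nM
Compound 3 `Cc1ccccc1C(=O)NN(C(=O)c1ccccc1Cl)C(C)(C)C` — 72.4 nM

All three were tested in an assay on cells for agonist activity at ecdysone receptor (Bombyx mori), read by a luciferase reporter, with a stated time of 24 h; on this read-out lower numbers stand for an effect already at smaller amounts and higher numbers for an effect only at larger amounts of compound. Among them, compound 3 gives the smallest number, but its gap to compound 1 is within the scatter, so these two cannot be told apart; only compound 2 stands clearly apart from compound 3, with a higher number beyond the scatter.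

Compound 4 `COc1ccc(C(=O)NN(C(=O)c2ccccc2Cl)C(C)(C)C)cc1` has not yet been measured. It differs from compound 3 in one place: 4-methoxyphenyl in place of 2-methylphenyl on a carbonyl carbon. Within the data shown here, only one measured step exists for comparison, and it concerns a different ring and a different exchange: a methoxy in place of iodo, which gave a 5.0-fold higher number from compound 1 to compound 2 (0.70 log units; beyond the scatter). That step says nothing directly about trading a methyl for a methoxy in the present position, so it bears on compound 4 only loosely, as a hint that a methoxy entering this shared core has so far gone with a higher number in this assay.

On that slim basis, compound 4 is expected to give a number somewhat higher than compound 3, a step of roughly a 2.8-fold higher number from compound 3 to compound 4 (0.44 log units; beyond the scatter), with wide uncertainty. The estimate for compound 4 in this assay is 200 nM, within a range from 60 nM to 700 nM.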

Compound 4, half-maximal effective concentration: 51.3 nM
The estimate for compound 4 lay 3.9-fold (0.59 log units) above the measured number; measured number outside the range, below it.
By their numbers in this assay, from the lowest: compounds 4, 3 and 1 (each within the scatter of the next, the first and the last beyond it); then compound 2.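

In this assay, among these compounds, the single change of group on the carbonyl carbon gives a 1.4-fold lower number from compound 3 to compound 4 (0.15 log units; within the scatter) and so leaves the two compounds indistinguishable. Among the compounds shown here, this place in the shared core therefore accepts a change of group, including the entry of a methoxy and a hydrogen-bond acceptor, with no shift beyond the scatter, which the earlier compounds could not show. The only earlier methoxy exchange, methoxy in place of iodo on an aromatic carbon, gave a 5.0-fold higher number from compound 1 to compound 2 (0.70 log units; beyond the scatter) and therefore does not hold as a general rule for methoxy in this series, while the data shown offer no explanation for the contrast.

On these data alone, what remains open is how far this tolerance extends at the same carbonyl carbon, for example whether a phenyl ring carrying an amine, a carboxylic acid or a longer chain such as butoxy would also leave the number within the scatter. It is also unknown whether 4-methoxyphenyl would behave in the same way if the group on the other carbonyl were changed, since compound 3 and compound 4 share that part of the structure.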